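Taking the methoxy group off compound 1

This account rests on a few compounds, and the source may have more. Where it says the series, first, only, none or still open, it means among the compounds named here.

For the measured compounds named here, in a functional assay on T47D cells (Homo sapiens) for inhibition, read by sulforhodamine B assay, with a stated time of 48 h, tested at 10 uM (on this read-out higher numbers stand for more inhibition of growth at the one concentration tested and lower numbers for less inhibition of growth), compound 1 `COc1ccc(-c2nc3sc(-c4ccccc4)cn3n2)cc1` gives 65%, the highest of the three numbers so far. Compound 3 `COc1ccc(-c2nc3sc(-c4ccc(Cl)cc4)cn3n2)cc1` gives 45.1%, and compound 2 `COc1cc(-c2nc(N)n(CC(=O)Nc3ccc(/C(C)=N\O)cc3)n2)cc(OC)c1OC`, which has a different core, gives 8.77%. Compound 4 `c1ccc(-c2nc3sc(-c4ccccc4)cn3n2)cc1` is still unmeasured. It differs from compound 1 by hydrogen in place of methoxy on an aromatic carbon. Going by the values given here, only one measured step offers a loose guide, chloro in place of hydrogen on an aromatic carbon, which gave a number 19.9 percentage points lower from compound 1 to compound 3 (beyond the scatter). Among the compounds with values here, that change lies elsewhere in the molecule, and no measured pair tests the methoxy itself. A modest drop in this assay is therefore expected, though its direction is uncertain. The expected step is a number 13 percentage points lower from compound 1 to compound 4 (beyond the scatter). For compound 4 the estimated value is 52%, within a range of 30% to 72%.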

Compound 4, percent growth inhibition at one concentration: 63%
For compound 4 the middle estimate is 11 percentage points below the measured one, within the range that was stated.
By their numbers in this assay, from the lowest: compound 2; then compound 3; then compounds 4 and 1 (each within the scatter of the next).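

Hydrogen in place of methoxy gives a number 2 percentage points lower from compound 1 to compound 4 (within the scatter) in this assay, so at this place, para to a large group, the two cannot be told apart on this read-out. For the compounds shown here, the only earlier single change, a number 19.9 percentage points lower from compound 1 to compound 3 (beyond the scatter), lies elsewhere in the molecule and left this position untested. Nothing available explains why the methoxy can be exchanged here without a step beyond the scatter. Still open, on these data alone, is whether an amine or a carboxylic acid at this place would also leave the number within the scatter. A longer chain such as butoxy is equally untested by the compounds shown.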